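This account rests on a few compounds, and the source may have more. Where it says the series, first, only, none or still open, it means among the compounds named here.

Measured so far:
- Compound 1 `Cc1ccc(S(=O)(=O)c2nc3ccccc3nc2Nc2ccccc2)cc1`: 12500 nM
- Compound 2 `Cc1ccc(S(=O)(=O)c2nc3ccccc3nc2Nc2cccc(N)c2)cc1`: 1950 nM
- Compound 3 `O=S(=O)(c1ccc(Br)cc1)c1nc2ccccc2nc1Nc1ccccc1`: 10800 nM

Not yet measured:
- Compound 4 `Nc1cccc(Nc2nc3ccccc3nc2S(=O)(=O)c2ccc(Br)cc2)c1`

In a functional assay on A549 cells (Homo sapiens) for cytotoxicity, read by MTT assay, with a stated time of 72 h (a higher number here means a weaker inhibitor, a lower number a stronger inhibitor), compound 3 gives 10800 nM. This value cannot be told apart from that of compound 1: putting bromo in place of methyl gave a 1.2-fold lower number from compound 1 to compound 3 (0.06 log units; within the scatter). Compound 2, at 1950 nM, has a clearly lower number than the other two.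

Compound 4 comes from compound 3 by one change: amino in place of hydrogen on an aromatic carbon. This is amino in place of hydrogen on an aromatic carbon, turning phenyl into 3-aminophenyl.

Among the compounds with values here, one measured step bears directly on this. The same change made on compound 1 gave a 6.4-fold lower number from compound 1 to compound 2 (0.81 log units; beyond the scatter), a modest gain. The bromo and methyl compounds behave alike within the scatter, so a similar gain is a reasonable expectation here. It remains a single example, and nothing yet shows that the gain carries over unchanged to the bromo compound, so the estimate is held slightly short of the full step and the range is kept wide.

The expected change is a 5.4-fold lower number from compound 3 to compound 4 (0.73 log units; beyond the scatter), towards a lower number. Compound 4 is estimated at 2000 nM, with an expected range of 700 nM to 6000 nM.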

Compound 4, half-maximal inhibitory concentration: 1120 nM
Estimate against measurement, compound 4: 1.8-fold (0.25 log units) above; the measured number falls inside the stated range.
By their numbers in this assay, from the lowest: compounds 4 and 2 (each within the scatter of the next); then compounds 3 and 1 (each within the scatter of the next).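

Turning phenyl into 3-aminophenyl also pays on the bromo compound in this assay, with a 9.6-fold lower number from compound 3 to compound 4 (0.98 log units; beyond the scatter), so this gain no longer rests on a single example. The size of the gain also holds up, as the two cores cannot be told apart on this change: the same change on two cores in this assay, a 6.4-fold lower number (0.81 log units; beyond the scatter) from compound 1 to compound 2 and a 9.6-fold lower number (0.98 log units; beyond the scatter) from compound 3 to compound 4, 1.5-fold (0.18 log units) apart, within the scatter of two such steps

The group at the other end of the molecule behaves differently: bromo in place of methyl still makes no difference beyond the scatter once the amino group is present, with a 1.7-fold lower number from compound 2 to compound 4 (0.24 log units; within the scatter), and the pairs with and without the amino group agree: the same change on two cores in this assay, a 1.2-fold lower number (0.06 log units; within the scatter) from compound 1 to compound 3 and a 1.7-fold lower number (0.24 log units; within the scatter) from compound 2 to compound 4, 1.5-fold (0.18 log units) apart, within the scatter of two such steps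

The compounds shown leave open whether the gain belongs to the amino group itself or would also come with a hydroxyl, a methoxy or a dimethylamino group in the same place on the ring. They also leave open whether groups other than methyl and bromo on the sulfonyl-bearing ring, such as a chlorine atom or a methoxy group, would stay as silent, and whether the pattern holds in any other cell line.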